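This account rests on a few compounds, and the source may have more. Where it says the series, first, only, none or still open, it means among the compounds named here.

Measured so far:
compound 1, `CC(C)=CCOc1cccc(O)c1C(=O)/C=C/c1ccc(O)cc1`: > 30000 nM
compound 2, `CC(C)CCCOc1cccc(O)c1C(=O)/C=C/c1ccc(O)cc1`: 11000 nM

In an assay on THP-1 cells for inhibition of nuclear factor NF-kappa-B complex (Homo sapiens), with stated times of 2 h and 16 h (on this read-out higher numbers stand for weaker inhibition and lower numbers for stronger inhibition), compound 1 gives only a limit, > 30000 nM; this is the limit of > 30000 nM in this assay, at which 1 of the 2 values shown sits, so where compound 1 truly stands on the numbers is not known, only that it is a weak inhibitor. In this assay compound 2 gives 11000 nM. Going by the values given here, the one measured step is an at least 2.7-fold lower number from compound 1 to compound 2 (0.43 log units; beyond the scatter), and because compound 1 sits at the limit of > 30000 nM in this assay, at which 1 of the 2 values shown sits, the true size of that step is open upward.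

Compound 3, `CCCCOc1cccc(O)c1C(=O)/C=C/c1ccc(O)cc1`, has not been measured in this assay. It differs from compound 1 by propyl in place of 2-methylprop-1-en-1-yl on a saturated chain carbon bound to an oxygen on an aromatic ring. The measured step from compound 1 to compound 2 bears directly on it: both changes replace 2-methylprop-1-en-1-yl with a saturated chain on the same carbon, isopentyl in compound 2 and propyl in compound 3, the shorter chain by the counts given. The expectation is a step of the same direction, toward a lower number, and of at least modest size, though propyl may not carry the whole effect seen with isopentyl; the step is estimated as an at least 2.0-fold lower number from compound 1 to compound 3 (0.30 log units; that floor lies within the scatter). Compound 3 is therefore expected at about 15000 nM, within 5000 nM to 45000 nM, with a real chance that this assay again reports only a limit.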

Compound 3, half-maximal inhibitory concentration: > 30000 nM
Compound 3 ended at the assay's limit; the forecaster's own chance of this, stated with the estimate: 35%; at least 2.0-fold (0.30 log units) between middle value and limit.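

In this assay compound 3 gives only a limit, > 30000 nM, and the step from compound 1 to compound 3 cannot be read: the limit of > 30000 nM in this assay, at which 2 of the 3 values shown sit.

The drop seen on going from compound 1 to compound 2 could, on those two compounds alone, have been read as following the loss of the chain's double bond. Compound 3 also lacks that double bond, yet methyl in place of isopropyl at the chain end gives an at least 2.7-fold higher number from compound 2 to compound 3 (0.43 log units; beyond the scatter), beyond the scatter, so a saturated chain at this position does not by itself give a measurable value in this series, and the end of the chain matters as well.

That one change both shortens the chain and removes its branch, and the compounds shown do not separate these two effects. A straight hexyl chain, or a cyclohexylmethyl group on the same oxygen, would test whether length or branching carries the step, and a terminal amine or carboxylic acid on the chain would show how far this position tolerates a charged group.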